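The source may hold more compounds than are shown below. What is called first, only, known or untested is meant among the compounds shown, and "the series" means these compounds.

In a functional assay on SK-MEL-5 cells (Homo sapiens) for inhibition, read by MTT assay, with a stated time of 48 h (a higher number here means a weaker inhibitor, a lower number a stronger inhibitor), compound 1 (`COc1ccccc1OCCNCC(O)COc1ccc2ccccc2c1`) gives 18500 nM while compound 2 (`OC(COc1ccc(-c2ccccc2)cc1)CN1CCN(c2ccccc2)CC1`) gives 12200 nM and compound 3 (`OC(CNCc1ccc(-c2ccccc2)cc1)COc1cccc(Nc2ccccc2)c1`) gives 3700 nM as the lowest of the three numbers, beyond the scatter from both others. Compound 4 (`c1ccc(Nc2cccc(OCCCNCc3ccc(-c4ccccc4)cc3)c2)cc1`) departs from compound 3 by one change (hydrogen in place of hydroxy on a saturated chain carbon bound to two saturated chain carbons), with hydrogen in place of hydroxy on a saturated chain carbon bound to two saturated chain carbons. Among the compounds with values here, no measured pair shows this change on its own, so the expectation remains uncertain. The expected step of a 1.1-fold higher number from compound 3 to compound 4 (0.03 log units; within the scatter) in this assay is small, with no shift beyond the scatter in either direction. For compound 4 the estimated value is 4000 nM within an expected range (1500 nM to 10000 nM).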

Compound 4, half-maximal inhibitory concentration: 4720 nM
The estimate for compound 4 lay 1.2-fold (0.07 log units) below the measured number; the measured number falls inside the stated range.
By their numbers in this assay, from the lowest: compounds 3 and 4 (each within the scatter of the next); then compounds 2 and 1 (each within the scatter of the next).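

Within the data shown here, the first reading of this position on its own comes in this assay, where hydrogen in place of hydroxy on a saturated chain carbon bound to two saturated chain carbons gives a 1.3-fold higher number from compound 3 to compound 4 (0.11 log units; within the scatter) and so brings no shift beyond the scatter. In this pair, the hydroxy is therefore not required for a number at this level. Nothing measured here offers an explanation for this result. From the compounds shown here alone, whether an amine or a methoxy group on this carbon would give a similar number remains open. Also open, going by these compounds, is whether losing the hydroxy would matter as little on the cores of compound 1 and compound 2.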